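The source may report more compounds than this note shows. Statements on the series, on what has been measured and on what is new or still open speak of the compounds shown alone.

Of the compounds shown here, two sharing one core have been measured so far in a physicochemical assay for solubility, read by LC-MS, in phosphate buffer, with a stated time of 24 h, at pH 6.8; on this read-out higher numbers stand for higher solubility and lower numbers for lower solubility. Compound 1 `C[C@@H](c1ccc(NC(=O)N2CC(c3ccc(N)nc3)C2)cc1)N1Cc2ccccc2C1=O` gives 220000 nM, and compound 2 `C[C@H](NC(=O)[C@@H]1CCCN1C)c1ccc(NC(=O)N2CC(c3ccc(N)nc3)C2)cc1` gives 760000 nM, the higher of the two numbers. Among the measured compounds shown here, the only measured step is a 3.5-fold higher number from compound 1 to compound 2 (0.54 log units; beyond the scatter). Compound 3 `CCC(=O)N[C@@H](C)c1ccc(NC(=O)N2CC(c3ccc(N)nc3)C2)cc1` departs from compound 2 in one place: ethyl in place of 1-methylpyrrolidin-2-yl on a carbonyl carbon. The 1-methylpyrrolidin-2-yl group is lost, and compound 1 also lacks that group. For the measured compounds named here, one step is thin evidence, and no measured compound carries the ethyl group, so the expectation is loose. Going by the values given here, the expected direction is downward, towards compound 1 at 220000 nM, with a size close to that of the one measured step, a 3.5-fold higher number from compound 1 to compound 2 (0.54 log units; beyond the scatter). The estimated step is a 2.7-fold lower number from compound 2 to compound 3 (0.43 log units; beyond the scatter). For compound 3 the expected value is 280000 nM, with an estimated range of 80000 nM to 800000 nM.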

Compound 3, solubility: 760000 nM
Compound 3: middle estimate off by 2.7-fold (0.43 log units), on the low side, within the range that was stated.
By their numbers in this assay, from the lowest: compound 1; then compounds 2 and 3 (each within the scatter of the next).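

In this assay, putting ethyl in place of 1-methylpyrrolidin-2-yl on the carbonyl carbon gives no change at the digits printed from compound 2 to compound 3 (within the scatter), so the smaller group without a ring holds the number reached with the ring. The other new comparison shows a 3.5-fold higher number from compound 1 to compound 3 (0.54 log units; beyond the scatter), which means that the rise over compound 1 seen earlier with the 1-methylpyrrolidin-2-yl group does not require that group. Nothing here measures why the two groups give the same number, or why both stand apart from compound 1.

From the compounds shown here alone, it remains open whether a longer chain, such as butyl, or an open-chain amine, such as dimethylaminomethyl, on the same carbonyl carbon would keep this number. Going by these compounds, a carboxylic acid in that place is equally open, as is whether any group there could move the number beyond the scatter.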